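A few compounds are considered here, and "the series" means these few. Any claim that something is new, unique, unknown or untested is made for them only; others in the source may bear on it.

In an assay on HEK293 cells for binding affinity to Urotensin-2 receptor (Homo sapiens), read by radioligand binding (on this read-out lower numbers stand for stronger inhibition and higher numbers for weaker inhibition), compound 1 `Cc1cc(C(=O)N[C@H]2CCN(Cc3ccc(OCCCN(C)C)cc3)C2)ccc1Cl` gives 631 nM. Compound 2 `Cc1cc(C(=O)N[C@H]2CCN(Cc3ccc(OCCCN(C)C)cc3)C2)ccc1Br` in this assay gives 631 nM, so the exchange of bromo for chloro on an aromatic carbon leaves no change at the digits printed from compound 1 to compound 2 (within the scatter). Compound 3 `CN(C)CCCOc1ccc(CN2CC[C@H](NC(=O)c3ccco3)C2)cc1` stands differently. In this assay the result for compound 3 is only a limit, < 10000 nM, and not a number. Because of the limit of < 10000 nM in this assay, at which 1 of the 3 values shown sits, the size of the change on going to the furan-2-yl group is hidden: the step that the limit leaves unreadable from compound 1 to compound 3 and the step that the limit leaves unreadable from compound 2 to compound 3 cannot be read.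

Compound 4 `CC(=O)N[C@H]1CCN(Cc2ccc(OCCCN(C)C)cc2)C1` has not yet been measured. It differs from compound 3 by methyl in place of furan-2-yl on a carbonyl carbon. Going by the values given here, the only measured steps at this carbonyl carbon are the two just described, and both are unreadable, so no measured step gives a size for the present change; compound 3 itself is known only as a limit. The expectation for compound 4 in this assay therefore rests on weak ground, and compound 4 is expected to sit close to the limit, with a number no lower from compound 3 to compound 4 (the limit leaves the size open) as the estimated step. The estimated value for compound 4 is 10000 nM, within a range from 2000 nM to 30000 nM.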

Compound 4, inhibition constant: < 10000 nM
Compound 4 was reported as a limit (the forecaster's own chance of this, stated with the estimate: 65%); the middle value lies on the limit itself.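

Compound 4, like compound 3, comes back only as a limit and not a number, so its steps from compound 1, compound 2 and compound 3 cannot be read: the limit of < 10000 nM in this assay, at which 2 of the 4 values shown sit.

The compounds shown leave open how far compound 3 and compound 4 lie from compound 1 and compound 2 in this assay, and whether furan-2-yl and methyl on the carbonyl carbon differ at all.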